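A few compounds are considered here, and "the series" means these few. Any claim that something is new, unique, unknown or untested is made for them only; others in the source may bear on it.

Compound 1 `O=C(Cn1cc(-c2ccc(F)cc2)nn1)Nc1nccs1`: 190 nM in a functional assay on BMDM cells (Mus musculus, strain C57BL/6) for inhibition, with a stated time of 2 days; a higher number here means a weaker inhibitor, a lower number a stronger inhibitor.
Compound 2 `Cc1cc(NC(=O)Cn2cc(-c3cccc(Cl)c3)nn2)no1`: in this assay compound 2 gives only the limit > 30000 nM.
Compound 3 `O=C(Cn1cc(-c2cccs2)nn1)Nc1nccs1`: in this assay compound 3 gives only the limit > 30000 nM.

Compound 3 sits at the limit of > 30000 nM in this assay, at which 2 of the 3 values shown sit, so for it only a limit and no number is known. Compound 4 `O=C(Cn1cc(-c2cccc(Cl)c2)nn1)Nc1nccs1` differs from compound 3 by 3-chlorophenyl in place of thiophen-2-yl on an aromatic carbon. Going by the values given here, the one measured step that bears on this change is an at least 150-fold higher number from compound 1 to compound 3 (2.19 log units; beyond the scatter), a large loss on taking up thiophen-2-yl; compound 4 returns to a six-membered carbon ring, though with a different halogen pattern. Compound 2, which also carries 3-chlorophenyl on another amide partner, gives only the limit > 30000 nM. A gain is therefore expected, an at least 20-fold lower number from compound 3 to compound 4 (1.30 log units; beyond the scatter), but with wide uncertainty. Compound 4 is estimated at 1500 nM, between 200 nM and 30000 nM.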

Compound 4, half-maximal inhibitory concentration: > 30000 nM
Compound 4 ended at the assay's limit (the forecaster's own chance of this, stated with the estimate: 35%); middle value at least 20-fold (1.30 log units) away from the limit.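

In this assay, 3-chlorophenyl in place of 4-fluorophenyl on this aromatic carbon gives an at least 150-fold higher number from compound 1 to compound 4 (2.19 log units; beyond the scatter), so a six-membered aromatic ring of carbon only does not by itself keep activity here. The steps to compound 4 from compound 2 and compound 3 cannot be read, since both ends are limits. Among the compounds shown, only compound 1 has a measured number, and the others share one limit: the limit of > 30000 nM in this assay, at which 3 of the 4 values shown sit.

Still open, going by these compounds, is whether the loss follows the change of halogen or its place on the ring. Plain phenyl, or an amine on that ring, would help separate these.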